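This account rests on a few compounds, and the source may have more. Where it says the series, first, only, none or still open, it means among the compounds named here.

Compound 1 `COC(=O)c1c(-c2cc(OC)cc(OC)c2)oc2ccccc2c1=O`: > 25 ug/mL
Compound 2 `COC(=O)c1c(-c2ccc(N)cc2)oc2ccccc2c1=O`: > 25 ug/mL

In a functional assay on MCF7 cells (Homo sapiens) for cytotoxicity, read by MTT assay, with a stated time of 6 days (a lower number here means that less compound is needed, a higher number that more compound is needed for the effect), compound 1 gives > 25 ug/mL, which is a limit and not a number. Compound 2 gives > 25 ug/mL, also a limit. The two measured compounds thus share one result: the limit of > 25 ug/mL in this assay, at which 2 of the 2 values shown sit.

Compound 3 `COc1cc(OC)cc(-c2oc3ccccc3c(=O)c2C(=O)O)c1` differs from compound 1 by hydrogen in place of methyl on an oxygen next to a carbonyl group, with hydrogen in place of methyl on an oxygen next to a carbonyl group, or methoxycarbonyl to carboxy. Going by the values given here, no measured step covers this change. Expected in this assay is a step that the limit leaves unreadable from compound 1 to compound 3, with no step beyond the scatter in either direction. For compound 3 the estimated value is 30 ug/mL, with an expected range from 20 ug/mL to 60 ug/mL.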

Compound 3, concentration for half-maximal effect: > 25 ug/mL
Compound 3: a limit, no number; the forecaster's own chance of this, stated with the estimate: 85%; the middle value lies beyond the limit too.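

Going by these compounds alone, compound 3 gives > 25 ug/mL as a limit and not a number, and compound 1 also stands at a limit, so no step between compound 1 and compound 3 can be read. In this assay the compounds shown leave open whether methoxycarbonyl to carboxy changes the result at all.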